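A few compounds are considered here, and "the series" means these few. Any claim that something is new, unique, unknown or untested is made for them only; others in the source may bear on it.

Two compounds have been measured in an ADME assay on PA-1 cells (Homo sapiens) for cytotoxicity, read by MTT assay, with a stated time of 72 h; a lower number here means a stronger inhibitor, a higher number a weaker inhibitor:
compound 1, `COc1ccc(C2=C(c3cc(OC)c(OC)c(OC)c3)C(=O)C(O)C2)cc1NC(=O)c1ccccc1` — > 100 ug/mL
compound 2, `COc1ccc(C2=C(c3cc(OC)c(OC)c(OC)c3)C(=O)CC2O[SiH2]C(C)(C)C)cc1O` — 14 ug/mL

The value for compound 1 is a limit of the assay rather than a number; it sits at the limit of > 100 ug/mL in this assay, at which 1 of the 2 values shown sits. Compound 2, in this assay, gives 14 ug/mL, a measured number. Within the data shown here, no single-change pair links these two measured compounds, so no measured step is available.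

Compound 3, `COc1ccc(C2=C(c3cc(OC)c(OC)c(OC)c3)C(=O)C(O)C2)cc1F`, is the next compound to be measured in this assay. It differs from compound 1 in one place: fluoro in place of benzamido on an aromatic carbon. Among the measured compounds shown here, since compound 1 stands only at a limit, the size of this step can only be guessed, and the one measured number, that of compound 2, gives no direct guide. The change is expected to bring the number down into the measured range, with an estimated step of an at least 2.5-fold lower number from compound 1 to compound 3 (0.39 log units; beyond the scatter), though a limit may again be reported. Compound 3 is expected to give about 40 ug/mL in this assay, within 10 ug/mL to 100 ug/mL.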

Compound 3, half-maximal inhibitory concentration: > 100 ug/mL
Compound 3: only a limit was reported; the forecaster's own chance of this, stated with the estimate: 45%; middle value at least 2.5-fold (0.39 log units) from the limit.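

Compound 1 and compound 3 both give a limit of the assay rather than a number, so no step can be read between them: the limit of > 100 ug/mL in this assay, at which 2 of the 3 values shown sit.

The compounds shown leave open whether fluoro in place of benzamido on an aromatic carbon changes the true value at all.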